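Swapping the oxazole substituent of compound 1

The compounds below may be only part of what the source reports. "The series", "measured", "known", "first", "only" and "open" are said of these compounds alone.

Measured compounds:
compound 1, `COC(=O)c1ccc(-c2cnc(C(=O)CCc3ccc(-c4ccccc4)cc3)o2)nc1` — 2.2 nM
compound 2, `COC(=O)c1ccc(-c2cnc(C(=O)CCc3ccc(Oc4ccccc4)cc3)o2)nc1` — 54 nM

Compound 1 was tested in an assay for inhibition of Fatty-acid amide hydrolase 1 (Rattus norvegicus) (a lower number here means a stronger inhibitor, a higher number a weaker inhibitor), and gave 2.2 nM. Among the compounds with values here, it holds the lowest of the two numbers in this assay; its only neighbour is compound 2, which in this assay gives 54 nM. Within the data shown here, the single measured step runs a 25-fold higher number from compound 1 to compound 2 (1.39 log units; beyond the scatter), and it concerns the phenoxy in place of phenyl on an aromatic carbon of the tail, not the group at the other end of the shared core.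

Compound 3, `O=C(CCc1ccc(-c2ccccc2)cc1)c1ncc(-c2cccnc2)o1`, has not been measured in this assay. Relative to compound 1 it carries pyridin-3-yl in place of 5-(methoxycarbonyl)pyridin-2-yl on an aromatic carbon. Among the measured compounds shown here, no measured step touches this end of the shared core, so the step from compound 1 to compound 2 gives no guide to the size or direction of the change. The expectation for compound 3 therefore rests on the value of compound 1 alone, with wide uncertainty, and a modest step of a 2.3-fold higher number from compound 1 to compound 3 (0.36 log units; beyond the scatter) toward a higher number is expected. Compound 3 is estimated at 5 nM, within 1.5 nM to 20 nM.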

Compound 3, inhibition constant: 1.1 nM
The estimate for compound 3 lay 4.5-fold (0.66 log units) above the measured number; measured number outside the range, below it.
By their numbers in this assay, from the lowest: compounds 3 and 1 (each within the scatter of the next); then compound 2.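

In this assay, within the data shown here, the step of a 2.0-fold lower number from compound 1 to compound 3 (0.30 log units; within the scatter) is the first measured reading at this end of the shared core, on the aromatic carbon next to the ring oxygen. It shows that 5-(methoxycarbonyl)pyridin-2-yl, with its 10 heavy atoms and 3 hydrogen-bond acceptors, can give way to pyridin-3-yl, with 6 heavy atoms and 1 hydrogen-bond acceptor, without a change beyond the scatter, whereas the tail exchange a 25-fold higher number from compound 1 to compound 2 (1.39 log units; beyond the scatter) lies beyond it. Nothing available here accounts for why this exchange stays within the scatter.

The exchange removes the methoxycarbonyl group and alters how the pyridine ring is attached in a single step, so the compounds shown cannot separate these two differences. They also leave open how a carboxylic acid or an amide would read in place of the methyl ester, how a plain phenyl ring would read at this position, and whether phenoxy in place of phenyl on the tail would give a similar step when pyridin-3-yl is present.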